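The source may hold more compounds than are shown below. What is called first, only, known or untested is meant among the compounds shown, and "the series" means these compounds.

Measured compounds in this series:

- compound 1, `CN(C)CC[C@H](CSc1ccccc1)Nc1ccc(S(=O)(=O)NC(=O)c2ccc(N3CCN(Cc4ccccc4-c4ccc(Cl)cc4)CC3)cc2)cc1C(F)(F)F`, in an assay on isolated protein for displacement of a labelled ligand from Apoptosis regulator Bcl-2 (Homo sapiens), read by fluorescence polarization; a higher number here means a weaker inhibitor, a lower number a stronger inhibitor: < 1 nM, which is a limit of the assay rather than a number.
- compound 2, `CN(C)CC[C@H](CSc1ccccc1)Nc1ccc(S(=O)(=O)NC(=O)c2ccc(N3CCN(CC4=C(c5ccc(Cl)cc5)CCCC4)CC3)cc2)cc1[N+](=O)[O-]`, in this assay: < 1 nM, likewise a limit and not a number.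

Compound 1 therefore stands only at a limit; no numerical inhibition constant is known for it. Among the measured compounds shown here, compound 2 gives the same kind of reading, and no step between the two is counted here, so the pair shows only that both sit at the same limit, as noted in the limit of < 1 nM in this assay, at which 2 of the 2 values shown sit.

The next compound, compound 3, `CN(C)CC[C@H](CSc1ccccc1)Nc1ccc(S(=O)(=O)NC(=O)c2ccc(N3CCN(Cc4ccccc4-c4ccc(Cl)cc4)CC3)cc2)cc1C#N`, differs from compound 1 in one place: cyano in place of trifluoromethyl on an aromatic carbon. The shared core of compound 1 is otherwise kept, as is the remainder of the structure.

With compound 1 resting at a limit, the direction of the step cannot be read from the data, and a single change of this kind is expected to move this assay by no more than the usual scatter. The expected step from compound 1 to compound 3 is a number no lower from compound 1 to compound 3 (the limit leaves the size open). Compound 3 is estimated to give 1 nM in this assay, within a range of 0.3 nM to 4 nM, and it may well again be reported only as a limit.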

Compound 3, inhibition constant: < 1 nM
Compound 3 was reported as a limit; the forecaster's own chance of this, stated with the estimate: 55%; the middle value sits exactly at the limit.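

Compound 1 and compound 3 both rest at a limit in this assay, so no new step can be read for cyano in place of trifluoromethyl on an aromatic carbon: the limit of < 1 nM in this assay, at which 3 of the 3 values shown sit.

The compounds shown leave open whether this exchange changes the inhibition constant at all, with no numerical value available for any of the three compounds.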